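Straightening the Amide Substituent of Compound 1

This account rests on a few compounds, and the source may have more. Where it says the series, first, only, none or still open, it means among the compounds named here.

Compound 1 `CC(C)NC(=O)/C=C1\CCc2ccc(F)cc21` was tested in a functional assay on the whole organism with Mus musculus as the target (a lower number here means that less compound is needed, a higher number that more compound is needed for the effect), where compound 1 gave 96 mg/kg, the highest of the three numbers measured. Compound 2 `CN(C)C(=O)/C=C1\CCc2c(F)cc(F)cc21` gave 50 mg/kg, a value within the scatter of compound 1. Compound 3 `Cc1cccc2c1CC/C2=C\C(=O)NC1CC1` gave 40 mg/kg, a lower number that lies beyond the scatter of compound 1. Compound 4 `CCCNC(=O)/C=C1\CCc2ccc(F)cc21` has not yet been measured in this assay. It differs from compound 1 by one change: propyl in place of isopropyl on an amide-type nitrogen. Within the data shown here, no measured pair shows a change of this kind, so no direction can be drawn from the data. The expected step of a 1.1-fold lower number from compound 1 to compound 4 (0.03 log units; within the scatter) is none beyond the scatter. Compound 4 is accordingly estimated at 90 mg/kg, with a range from 40 mg/kg to 200 mg/kg.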

Compound 4, dose for half-maximal effect: > 100 mg/kg
Compound 4: a limit, no number; the forecaster's own chance of this, stated with the estimate: 10%; at least 1.1-fold (0.04 log units) between middle value and limit.
By their numbers in this assay, from the lowest: compounds 3, 2 and 1 (each within the scatter of the next, the first and the last beyond it). At a limit, above all of these: compound 4.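

In this assay compound 4 gives > 100 mg/kg, which is a limit and not a number: the limit of > 100 mg/kg in this assay, at which 1 of the 4 values shown sits. This gives the first step read at the amide-type nitrogen, an at least 1.0-fold higher number from compound 1 to compound 4 (0.01 log units; that floor lies within the scatter), so propyl in place of isopropyl brought no lower number here, and only a floor is known for the size of the step. The compounds shown leave open whether ethyl or butyl on this nitrogen, or a propyl chain ending in an amine, would give a number rather than a limit.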